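Trading phenyl for a triazole carbonyl on compound 3

A few compounds are considered here, and "the series" means these few. Any claim that something is new, unique, unknown or untested is made for them only; others in the source may bear on it.

- compound 1 `O=C(c1ccccc1)N1CCC(C(=O)N2N=CCC2c2ccccc2)CC1` gives 0.0833 h
- compound 2 `O=C(c1cn[nH]c1)N1CCC(C(=O)N2N=CCC2c2ccccc2)CC1` gives > 2.75 h as a limit, not a number
- compound 3 `O=C(C1CCN(c2ccccc2)CC1)N1N=CCC1c1ccccc1` gives 0.25 h

In an ADME assay on microsomes (Rattus norvegicus) for metabolic stability (on this read-out lower numbers stand for a shorter-lived compound and higher numbers for a longer-lived compound), compound 3 gives the higher of the two plain numbers (0.25 h), and the rise to it is modest (a 3.0-fold higher number from compound 1 to compound 3 (0.48 log units; beyond the scatter)). Compound 2 reports only a limit (> 2.75 h).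

Compound 4 `O=C(c1c[nH]nn1)N1CCC(C(=O)N2N=CCC2c2ccccc2)CC1` has not been measured yet. It carries (1H-1,2,3-triazol-4-yl)carbonyl in place of phenyl on an amine nitrogen in a ring.

Among the compounds with values here, two measured steps bear on this change. One is large and puts phenyl in place of (1H-pyrazol-4-yl)carbonyl on that same amine nitrogen (an at least 11-fold lower number from compound 2 to compound 3 (1.04 log units; beyond the scatter)), so the opposite kind of exchange points upward. The other is also large, with 1H-pyrazol-4-yl in place of phenyl on a carbonyl carbon (an at least 33-fold higher number from compound 1 to compound 2 (1.51 log units; beyond the scatter)).

A large rise is therefore expected (a 10-fold higher number from compound 3 to compound 4 (1.00 log units; beyond the scatter)). Compound 4 is estimated at 2.5 h with an expected range from 0.8 h to 4 h on this measure.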

Compound 4, half-life: > 2.75 h
Compound 4: only a limit was reported; the forecaster's own chance of this, stated with the estimate: 55%; middle value at least 1.1-fold (0.04 log units) from the limit.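

In this assay, the new step of an at least 11-fold higher number from compound 3 to compound 4 (1.04 log units; beyond the scatter) shows that on this amine nitrogen, (1H-1,2,3-triazol-4-yl)carbonyl gives a far longer-lived compound than phenyl, so the earlier rise with the pyrazole is not a one-off. A carbonyl at this position is not enough on its own, as compound 1 also carries one and stays short-lived, while changing only the ring on that carbonyl gives an at least 33-fold higher number from compound 1 to compound 4 (1.51 log units; beyond the scatter). Both steps are minimum sizes, since compound 4 reports only a limit.

No order can be read between compound 2 and compound 4, since the step between them cannot be read with both values stopping at the same limit: the limit of > 2.75 h in this assay, at which 2 of the 4 values shown sit.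
Going by these compounds, whether a pyridine ring or a simple methyl group on that carbonyl would also give a long-lived compound stays open.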